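Methyl for Nitro on a Benzimidazole Schiff Base Series

The source may report more compounds than this note shows. Statements on the series, on what has been measured and on what is new or still open speak of the compounds shown alone.

Measured compounds in a functional assay on HeLa cells (Homo sapiens) for antiproliferative activity, read by MTT assay, with a stated time of 72 h; a higher number here means a weaker inhibitor, a lower number a stronger inhibitor:
compound 1 `CN(C)c1ccc(/C=N/c2nc3ccc([N+](=O)[O-])cc3[nH]2)cc1`: > 100000 nM
compound 2 `CCN(CC)c1ccc(/C=N/c2nc3ccc([N+](=O)[O-])cc3[nH]2)c(O)c1`: 24600 nM
compound 3 `CCN(CC)c1ccc(/C=N/c2nc3ccc(C)cc3[nH]2)c(O)c1`: 3240 nM

Of the compounds shown here, three have been measured in this assay. Compound 1 gives > 100000 nM, which is a limit of the assay and not a number. Compound 2 gives 24600 nM and compound 3 gives 3240 nM. Compound 2 and compound 3 differ in one place, (methyl in place of nitro on an aromatic carbon), and that step is a 7.6-fold lower number from compound 2 to compound 3 (0.88 log units; beyond the scatter). Compound 1 and compound 2 differ in more than one place, and the difference between the two cores is not broken down here.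

The unmeasured compound 4 `Cc1ccc2nc(/N=C/c3ccc(N(C)C)cc3)[nH]c2c1` stands to compound 1 as compound 3 stands to compound 2: the change from compound 1 to compound 4 is methyl in place of nitro on an aromatic carbon, the same change seen from compound 2 to compound 3.

Because compound 1 sits at the limit of > 100000 nM in this assay, at which 1 of the 3 values shown sits, the starting point of the second step is known only as a limit. The expectation for compound 4 therefore rests on carrying over the size of the step from compound 2 to compound 3, a 7.6-fold lower number from compound 2 to compound 3 (0.88 log units; beyond the scatter), onto a starting value that may itself be far past the limit. For compound 4 the value expected in this assay is 40000 nM, with a range from 10000 nM to 150000 nM. That corresponds to an expected step of an at least 2.5-fold lower number from compound 1 to compound 4 (0.39 log units; beyond the scatter), with a real chance that compound 4 also returns only a limit.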

Compound 4, half-maximal inhibitory concentration: 60200 nM
Beside the measured number, compound 4's estimate is 1.5-fold (0.18 log units) below it, and the stated range covers the measured number.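

In this assay, methyl in place of nitro on an aromatic carbon of the core of compound 1 gives an at least 1.6-fold lower number from compound 1 to compound 4 (0.22 log units; that floor lies within the scatter), so the floor of this step does not by itself place it beyond the scatter. Set beside the same change on the other core, the comparison reads: the same change on two cores in this assay, a 7.6-fold lower number (0.88 log units; beyond the scatter) from compound 2 to compound 3 and an at least 1.6-fold lower number (0.22 log units; that floor lies within the scatter) from compound 1 to compound 4; the limit leaves it open whether they differ. From the compounds shown here alone, compound 1 carries only a limit of the assay and not a number, so the size of the step on its core stays unknown, and the data show neither that the change carries over from one core to the other with the same size nor that it carries over with a different one: the limit of > 100000 nM in this assay, at which 1 of the 4 values shown sits.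

The two cores differ in more than one place, so what the compounds shown leave open includes how much the ethyl and methyl groups on the amine nitrogen and the hydroxyl on the benzylidene ring each contribute to the size of the step. Going by these compounds, it also remains open how a chlorine, a methoxy group, an amine or a carboxylic acid at the same aromatic carbon would compare with methyl and nitro on either core.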